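The compounds below may be only part of what the source reports. "The series", "measured", "known", "first", "only" and "open" are said of these compounds alone.

Compounds measured in an assay on isolated protein (strain albino) for antagonist activity at Voltage-dependent L-type calcium channel subunit alpha-1C (Cavia porcellus); a higher number here means a weaker inhibitor, a lower number a stronger inhibitor:
- compound 1, `COC(=O)C1=C(C)NC(C)=C(C(=O)OC)C1c1cnc(SC)n1Nc1ccccc1`: 3.54 nM
- compound 2, `COC(=O)C1=C(C)NC(C)=C(C(=O)OC(C)C)C1c1cnc(SC)n1Nc1ccccc1`: 6.35 nM

Compound 2 stands beside compound 1 rather than apart from it: a 1.8-fold higher number from compound 1 to compound 2 (0.25 log units; within the scatter), so the two numbers are not distinguished by this assay. Compound 3, `COC(=O)C1=C(C)NC(C)=C(C(=O)OCc2ccccc2)C1c1cnc(SC)n1Nc1ccccc1`, is the next member of the series and has not yet been measured. It differs from compound 2 in one place: benzyl in place of isopropyl on an oxygen next to a carbonyl group. Within the data shown here, only one measured step bears on this change, the one at the same oxygen, a 1.8-fold higher number from compound 1 to compound 2 (0.25 log units; within the scatter), which stayed within the scatter although the group on that oxygen grew. Among the measured compounds shown here, on that basis the further growth to benzyl is expected to give at most a small step in this assay, with no clear direction beyond the scatter; the estimate leans slightly toward a higher number only because the one step in hand, a 1.8-fold higher number from compound 1 to compound 2 (0.25 log units; within the scatter), pointed that way. Compound 3 is therefore estimated at 7.5 nM, between 3 nM and 18 nM, which corresponds to an expected 1.2-fold higher number from compound 2 to compound 3 (0.07 log units; within the scatter).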

Compound 3, half-maximal inhibitory concentration: 2.21 nM
Beside the measured number, compound 3's estimate is 3.4-fold (0.53 log units) above it, outside the stated range (below it).
By their numbers in this assay, from the lowest: compounds 3, 1 and 2 (each within the scatter of the next, the first and the last beyond it).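

In this assay, the oxygen next to a carbonyl group now gives its first step beyond the scatter: a 2.9-fold lower number from compound 2 to compound 3 (0.46 log units; beyond the scatter), so the choice between isopropyl and benzyl at this position can be read in this assay. The other new step, a 1.6-fold lower number from compound 1 to compound 3 (0.20 log units; within the scatter), means that methyl and benzyl on this oxygen are not told apart, so the numbers do not rise steadily as the group grows, and compound 3, with the largest group of the three, goes against any such trend. Nothing measured on these compounds bears on why benzyl and isopropyl differ here.

The compounds shown leave open whether the six-membered aromatic ring of the benzyl group matters, since a cyclohexylmethyl group or a longer chain ending in phenyl would be needed to separate the ring from the size of the group. They also leave open how a chain carrying an amine or a carboxylic acid would fare on this oxygen, as every group shown here consists of carbon and hydrogen alone.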